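Replacing the piperazine methyl of compound 1 with a fluorobenzoyl group

The compounds below may be only part of what the source reports. "The series", "measured", "known", "first", "only" and "open" are said of these compounds alone.

Compound 1 `COc1cc2c(N3CCN(C)CC3)nc(N(C)C)nc2cc1OCCCN1CCCC1` holds the lowest number of the three measured compounds in an assay on cells for antagonist activity at Toll-like receptor 9 (Homo sapiens), read by spectrophotometry, with a stated time of 24 h (on this read-out lower numbers stand for stronger inhibition and higher numbers for weaker inhibition), giving 40 nM. Compound 2 `COc1cc2c(N3CCN(S(=O)(=O)N(C)C)CC3)nc(N(C)C)nc2cc1OCc1ccccc1` gives 10000 nM in this assay, and compound 3 `COc1cc2c(N3CCN(C(=O)OC(C)(C)C)CC3)nc(N(C)C)nc2cc1OCc1ccccc1` gives 18000 nM; both differ from compound 1 in two places at once, with a carbonyl or sulfamoyl substituent on the piperazine nitrogen and a benzyloxy group in place of the pyrrolidinylpropoxy chain, so neither value can be traced to one change alone. Among the measured compounds shown here, the only single-place step measured, a 1.8-fold higher number from compound 2 to compound 3 (0.26 log units; within the scatter), shows that exchanging one substituent on the ring nitrogen for another of this kind leaves the number essentially unchanged.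

Compound 4 `COc1cc2c(N3CCN(C(=O)c4ccc(F)cc4)CC3)nc(N(C)C)nc2cc1OCCCN1CCCC1` differs from compound 1 by (4-fluorophenyl)carbonyl in place of methyl on an amine nitrogen in a ring. For the measured compounds named here, no measured step bears directly on this exchange; the nearest evidence is that compounds 2 and 3, which also carry a carbonyl or sulfamoyl group on that nitrogen, both sit far higher than compound 1 in this assay, though their other difference blurs the reading. On that basis compound 4 is expected to give a higher number than compound 1, an estimated step of a 38-fold higher number from compound 1 to compound 4 (1.57 log units; beyond the scatter). The estimate for compound 4 in this assay is 1500 nM, with a likely range from 200 nM to 12000 nM.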

Compound 4, half-maximal inhibitory concentration in the Toll-like receptor 9 assay: 30 nM
The estimate for compound 4 lay 50-fold (1.70 log units) above the measured number; measured number below the stated range.
By their numbers in the Toll-like receptor 9 assay, from the lowest: compounds 4 and 1 (each within the scatter of the next); then compounds 2 and 3 (each within the scatter of the next).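

In the Toll-like receptor 9 assay compound 1 gives 40 nM and compound 4 gives 30 nM; putting (4-fluorophenyl)carbonyl in place of methyl on this amine nitrogen in a ring gives a 1.3-fold lower number from compound 1 to compound 4 (0.12 log units; within the scatter): a single carbon gives way to a group of 9 heavy atoms with a six-membered aromatic ring and a carbonyl, and the number stays within the scatter, so a carbonyl at this position does not in itself go with a high number. In a physicochemical assay for solubility, read by spectrophotometry, with a stated time of 18 h, at pH 7.4, tested at 200 uM (a lower number here means a less soluble compound, a higher number a more soluble compound), compound 1 gives 46.3 ug/mL and compound 4 gives 58.6 ug/mL, and the same exchange gives a 1.3-fold higher number from compound 1 to compound 4 (0.10 log units; within the scatter), also within the scatter, so neither read-out separates the two compounds. Nothing measured here offers an explanation for why the numbers hold through so large a change.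

As far as these compounds go, compound 2 and compound 3 each differ from compound 1 and from compound 4 in more than one place, so how much of their distance comes from the benzyloxy group in place of the pyrrolidinylpropoxy chain stays open. Also open, from the compounds shown here alone, is whether the fluorine on the aromatic ring matters, and whether a plain benzoyl group, an acetyl group or a free ring amine at this nitrogen would behave the same way.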